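Triazole Acetamides: Swapping Methoxyphenyl for Aminophenyl

The source may hold more compounds than are shown below. What is called first, only, known or untested is meant among the compounds shown, and "the series" means these compounds.

Measured so far:
compound 1 `COc1ccc(-c2cn(CC(=O)Nc3nc4ccccc4s3)nn2)cc1` — 1330 nM
compound 2 `CCOc1cc(C(=O)Nc2nccs2)cc(OCC)c1OCC` — 6750 nM
compound 3 `Cc1csc(NC(=O)Cn2cc(-c3ccncc3)nn2)n1` — 100 nM

In a functional assay on BMDM cells (Mus musculus, strain C57BL/6) for inhibition, with a stated time of 2 days (on this read-out higher numbers stand for weaker inhibition and lower numbers for stronger inhibition), compound 1 gives 1330 nM, the second highest of the three numbers. Its nearest neighbour is compound 2 with 6750 nM, a higher number beyond the scatter, while compound 3 with 100 nM stands furthest away, a lower number beyond the scatter.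

Compound 4 `Nc1cccc(-c2cn(CC(=O)Nc3nc4ccccc4s3)nn2)c1` keeps the core of compound 1 and differs in one place: 3-aminophenyl in place of 4-methoxyphenyl on an aromatic carbon. Going by the values given here, no pair of measured compounds differs in this place alone, so nothing shows the size of this step directly. The step of a 1.3-fold lower number from compound 1 to compound 4 (0.12 log units; within the scatter) is expected to be modest, likely within the scatter. Compound 4 is therefore estimated at 1000 nM, with a range from 250 nM to 4000 nM.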

Compound 4, half-maximal inhibitory concentration: 1110 nM
The estimate for compound 4 lay 1.1-fold (0.05 log units) below the measured number; the measured number falls inside the stated range.
By their numbers in this assay, from the lowest: compound 3; then compounds 4 and 1 (each within the scatter of the next); then compound 2.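

In this assay, going by these compounds alone, the exchange gives a 1.2-fold lower number from compound 1 to compound 4 (0.08 log units; within the scatter) and so gives the first reading at this aromatic carbon: 3-aminophenyl can stand in place of 4-methoxyphenyl with the result within the scatter. The group that enters carries a hydrogen-bond donor and the group that leaves carries none, yet the two compounds stay within the scatter of each other. No measurement at hand offers an explanation for this. As far as these compounds go, how 4-aminophenyl or 3-methoxyphenyl would read at this carbon stays open, so the two differences within this exchange remain unseparated. From the compounds shown here alone, a carboxylic acid on this phenyl ring is equally open.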